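Pentafluoroethyl on the Core of Compound 1

The source may hold more compounds than are shown below. What is called first, only, known or untested is meant among the compounds shown, and "the series" means these compounds.

Compound 1 `O=C(Nc1cc(C(F)(F)F)cc(C(F)(F)F)c1)c1cnc(Cl)nc1`: 300 nM
Compound 2 `Cc1cc(C(=O)Nc2cc(C(F)(F)F)cc(C(F)(F)F)c2)nc(Cl)n1`: > 10000 nM, a limit of the assay
Compound 3 `O=C(Nc1cc(C(F)(F)F)cc(C(F)(F)F)c1)c1cnc(C(F)(F)F)nc1`: > 10000 nM, a limit of the assay

Among the compounds with values here, in an assay on Jurkat cells for activation of nuclear factor NF-kappa-B complex (Homo sapiens) (a higher number here means a weaker inhibitor, a lower number a stronger inhibitor), compound 1 gives 300 nM, the only genuine number among the three compounds measured. The other two values sit at the limit of > 10000 nM in this assay, at which 2 of the 3 values shown sit, and compound 1 is therefore the reference point for this series.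

Compound 4 `O=C(Nc1cc(C(F)(F)F)cc(C(F)(F)F)c1)c1cnc(Cl)nc1C(F)(F)C(F)(F)F` differs from compound 1 by 1,1,2,2,2-pentafluoroethyl in place of hydrogen on an aromatic carbon. Within the data shown here, no measured step places exactly this group, so the two known steps from compound 1 serve as the nearest guides. The step of an at least 33-fold higher number from compound 1 to compound 2 (1.52 log units; beyond the scatter) brought a methyl group onto the core together with a shift of the attachment point; the step of an at least 33-fold higher number from compound 1 to compound 3 (1.52 log units; beyond the scatter) replaced the chloro group with trifluoromethyl. Both changes to the core of compound 1 ended at the limit, and both were large. A pentafluoroethyl group entering the core is a change of the same kind and larger in bulk, so compound 4 is expected to move in the same direction, toward weaker inhibition, by a large step, a 20-fold higher number from compound 1 to compound 4 (1.30 log units; beyond the scatter). Compound 4 is estimated at 6000 nM, with a range from 1500 nM to 30000 nM.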

Compound 4, half-maximal inhibitory concentration: 800 nM
Compound 4: middle estimate off by 7.5-fold (0.88 log units), on the high side, and the stated range ends above it.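

In this assay, the aromatic carbon next to the ring nitrogen and ortho to a large group accepts 1,1,2,2,2-pentafluoroethyl in place of hydrogen at only a modest cost, with the change giving a 2.7-fold higher number from compound 1 to compound 4 (0.43 log units; beyond the scatter). This shows that the core of compound 1 is not closed to every addition, and that a group of this kind at this place, with the chloro group kept, still leaves a genuine number rather than a limit of the assay, whereas both earlier changes to the core ended at such a limit: the limit of > 10000 nM in this assay, at which 2 of the 4 values shown sit.

Within the data shown here, the one earlier change that touched the chloro group replaced it, giving an at least 33-fold higher number from compound 1 to compound 3 (1.52 log units; beyond the scatter), so the large loss seen there now stands apart from what an added group does at this neighbouring place.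

On these data alone, what remains open is how an ethyl chain, a methoxy group or an amine would behave on this same carbon, so the modest step cannot yet be tied to pentafluoroethyl itself rather than to any group placed there. Also open, as far as these compounds go, is whether a carboxylic acid or an amine at this place could bring the number back to that of compound 1 or past it.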